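Anticonvulsant series: ortho-chloro removal on the benzoyl ring

A few compounds are considered here, and "the series" means these few. Any claim that something is new, unique, unknown or untested is made for them only; others in the source may bear on it.

Working notes on a small set of benzophenone glycinamides measured in a functional assay on the whole organism for antagonist activity, with Mus musculus as the target; on this read-out lower numbers stand for an effect already at smaller amounts and higher numbers for an effect only at larger amounts of compound. Compound 3 `CC(=O)NCC(=O)Nc1ccc(Cl)cc1C(=O)c1ccccc1Cl` reaches only the limit of this assay, > 100 mg/kg. Compound 1 `CC(=O)NCC(=O)Nc1ccc(Cl)cc1C(=O)c1ccccc1` gives 37 mg/kg. The change from compound 3 to compound 1 is hydrogen in place of chloro on an aromatic carbon, and it brought an at least 2.7-fold lower number from compound 3 to compound 1 (0.43 log units; beyond the scatter); with compound 3 sitting at the limit of > 100 mg/kg in this assay, at which 1 of the 3 values shown sits, the true size of that step is not known. Compound 2 `CN(C(=O)CNC(=O)c1ccccc1)c1ccc(Cl)cc1C(=O)c1ccccc1Cl` gives 2.9 mg/kg in this assay, the lowest number of the set. The difference between the core of compound 2 and the core of compound 3 is not broken down here.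

Compound 4 `CN(C(=O)CNC(=O)c1ccccc1)c1ccc(Cl)cc1C(=O)c1ccccc1` is not yet measured. It differs from compound 2 by hydrogen in place of chloro on an aromatic carbon, the same change as from compound 3 to compound 1, at the same place. From compound 2 to compound 4 a step of a 1.9-fold lower number from compound 2 to compound 4 (0.29 log units; within the scatter) is expected in this assay, resting on the measured step of an at least 2.7-fold lower number from compound 3 to compound 1 (0.43 log units; beyond the scatter). Compound 4 is estimated at 1.5 mg/kg, with the likely range from 0.5 mg/kg to 5 mg/kg.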

Compound 4, dose for half-maximal effect: 7.6 mg/kg
Compound 4: middle estimate off by 5.1-fold (0.70 log units), on the low side; measured number outside the range, above it.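

In this assay, hydrogen in place of chloro on an aromatic carbon brings a 2.6-fold higher number from compound 2 to compound 4 (0.42 log units; beyond the scatter), which runs opposite to the step seen on the core of compound 3, so this change cannot be carried from one core to the other in this series as a constant shift: the same change on two cores in this assay, an at least 2.7-fold lower number (0.43 log units; beyond the scatter) from compound 3 to compound 1 and a 2.6-fold higher number (0.42 log units; beyond the scatter) from compound 2 to compound 4, at least 7.0-fold (0.85 log units) apart, beyond the scatter of two such steps

Compound 3 stands at a limit of the assay and not at a number, so the gap between the two steps is known only as a bound: the limit of > 100 mg/kg in this assay, at which 1 of the 4 values shown sits.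

The two pairs show that the core decides the direction of the change, but not which part of the core does so or why, as the compounds shown do not break down the difference between the two cores.

From the compounds shown here alone, it remains open which part of that core difference reverses the step. Also open, going by these compounds, is whether fluoro or methoxy on the same aromatic carbon would follow chloro or hydrogen on either core.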